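Bromophenyl amides: from compound 2 to compound 3

The source may report more compounds than this note shows. Statements on the series, on what has been measured and on what is new or still open speak of the compounds shown alone.

Values in a functional assay on A549 cells (Homo sapiens) for antiproliferative activity, read by MTT assay, with a stated time of 48 h; a higher number here means a weaker inhibitor, a lower number a stronger inhibitor:
- compound 1 `COc1cccc(C(=O)Nc2nnc(/C=C/c3cc(OC)c(OC)c(OC)c3Br)s2)c1`: 60 nM
- compound 2 `COc1cc(/C=C/c2nnc(NC(=O)c3ccccc3Br)s2)c(Br)c(OC)c1OC`: 210 nM
- compound 3 `COc1cc(/C=C/c2nnc(NC(=O)c3ccc(Br)cc3)s2)c(Br)c(OC)c1OC`: not yet measured

Compound 2 has the higher number of the two measured compounds, at 210 nM. The change to compound 3 is 4-bromophenyl in place of 2-bromophenyl on a carbonyl carbon, with 4-bromophenyl in place of 2-bromophenyl on a carbonyl carbon. For the measured compounds named here, one measured step bears on this place: a 3.5-fold higher number from compound 1 to compound 2 (0.54 log units; beyond the scatter), modest and beyond the scatter. It shows that this place can shift the number, but it never tests 4-bromophenyl, so direction remains weakly supported. A small move toward a lower number is expected: a 1.5-fold lower number from compound 2 to compound 3 (0.18 log units; within the scatter). For compound 3 the estimated value is 140 nM, within an expected range of 45 nM to 420 nM.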

Compound 3, half-maximal inhibitory concentration: 160 nM
For compound 3 the middle estimate is 1.1-fold (0.06 log units) below the measured one; the range from low to high includes it.
By their numbers in this assay, from the lowest: compound 1; then compounds 3 and 2 (each within the scatter of the next).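

In this assay, 4-bromophenyl in place of 2-bromophenyl on a carbonyl carbon gives a 1.3-fold lower number from compound 2 to compound 3 (0.12 log units; within the scatter), so these two bromophenyl amides are not separated. The second bromophenyl amide also sits apart from the 3-methoxyphenyl amide, with a 2.7-fold higher number from compound 1 to compound 3 (0.43 log units; beyond the scatter), which makes that gap hold for both bromine placements shown. No measurement on hand accounts for this gap.

Going by these compounds, whether the gap follows the methoxy group or its place on the ring remains open. A 4-methoxyphenyl or 3-aminophenyl amide would test this.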